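Amide to amine step in the agonist series

The compounds below may be only part of what the source reports. "The series", "measured", "known", "first", "only" and "open" are said of these compounds alone.

Compound 2 `CS(=O)(=O)c1cnc(O[C@H]2CC[C@H](OC3CCN(C(=O)C4(C(F)(F)F)CCCC4)CC3)CC2)cn1` gives 124% in a functional assay on isolated protein for agonist activity at Glucose-dependent insulinotropic receptor (Rattus norvegicus), read by HTRF and cAMP accumulation; on this read-out higher numbers stand for larger maximal responses and lower numbers for smaller maximal responses; compound 1 `C[C@@H](CF)OC(=O)N1CCC(O[C@H]2CC[C@H](Oc3cnc(S(C)(=O)=O)cn3)CC2)CC1` gives 123% in this assay, and the step of a number 1 percentage points higher from compound 1 to compound 2 (within the scatter) lies within the scatter, so the two stand level. Compound 3 `CS(=O)(=O)c1cnc(O[C@H]2CC[C@H](OC3CCN(CC4(C(F)(F)F)CCCC4)CC3)CC2)cn1` differs from compound 2 by a group of 10 heavy atoms (7 carbon, 3 fluorine; one five-membered non-aromatic ring of carbon only) in place of a group of 11 heavy atoms (7 carbon, 1 oxygen, 3 fluorine; one five-membered non-aromatic ring of carbon only), on an amine nitrogen in a ring. Going by the values given here, no measured step removes the carbonyl itself; the only measured step exchanged the group on the carbonyl carbon and left the maximal response unchanged. The expected step is therefore uncertain, assumed small to moderately downward, a number 14 percentage points lower from compound 2 to compound 3 (beyond the scatter). Compound 3 is expected to reach 110%, within 75% to 135%.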

Compound 3, largest response reached (Emax), in percent of the reference or control that the assay uses: 88%
The estimate for compound 3 lay 22 percentage points above the measured number; the range from low to high includes it.
By their numbers in this assay, from the lowest: compound 3; then compounds 1 and 2 (each within the scatter of the next).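

Going by these compounds alone, replacing the carbonyl-bearing group on the amine nitrogen in a ring with the saturated group of compound 3 is the first change here to move the response in this assay (a number 36 percentage points lower from compound 2 to compound 3 (beyond the scatter)) and (a number 35 percentage points lower from compound 1 to compound 3 (beyond the scatter)). The exchange on the carbonyl carbon left compounds 1 and 2 level, so among these three compounds only the loss of the carbonyl goes with a lower maximal response. Nothing measured here explains the drop.

Still open, as far as these compounds go, is whether a sulfonyl or urea link on that nitrogen would hold the response. From the compounds shown here alone, a smaller group on the amine, such as cyclopropylmethyl, also remains untested in its effect on this read-out.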